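From piperazin-1-yl to 4-aminopiperidin-1-yl in compound 3

This account rests on a few compounds, and the source may have more. Where it says the series, first, only, none or still open, it means among the compounds named here.

In a functional assay on V79 cells (Cricetulus griseus) for cytotoxicity, read by colony formation (on this read-out lower numbers stand for stronger inhibition and higher numbers for weaker inhibition), compound 3 `O=C(O)c1cn(C2CC2)c2c(C(F)(F)F)c(N3CCNCC3)c(F)cc2c1=O` gives 1650 ug/mL, the highest number of the three measured compounds. Compound 1 `CNCC1(C)CCN(c2c(F)cc3c(=O)c(C(=O)O)cn(C4CC4)c3c2C(F)(F)F)C1` gives 230 ug/mL and compound 2 `O=C(O)c1cn(C2CC2)c2c(F)c(N3CCNCC3)c(F)cc2c1=O` gives 47 ug/mL.

Compound 4 `NC1CCN(c2c(F)cc3c(=O)c(C(=O)O)cn(C4CC4)c3c2C(F)(F)F)CC1` keeps everything in compound 3 except one group: it has 4-aminopiperidin-1-yl in place of piperazin-1-yl on an aromatic carbon, ortho to a fluoro group and ortho to a trifluoromethyl group. The change is 4-aminopiperidin-1-yl in place of piperazin-1-yl on an aromatic carbon.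

Two measured steps lead to compound 3. The larger, a 35-fold higher number from compound 2 to compound 3 (1.55 log units; beyond the scatter), is trifluoromethyl in place of fluoro. Compound 4 keeps the trifluoromethyl group, so that step says little about this exchange. The more relevant step is the modest 7.2-fold higher number from compound 1 to compound 3 (0.86 log units; beyond the scatter), which exchanges a group on the same aromatic carbon, with piperazin-1-yl entering in place of 3-methyl-3-((methylamino)methyl)pyrrolidin-1-yl.

Going by these compounds, that single pair makes no rule, and 4-aminopiperidin-1-yl itself is untested. Going by the values given here, still, the one other group measured there, in compound 1 at 230 ug/mL, has a lower number, so a modest step downward is expected in this assay. The expected change is a 3.0-fold lower number from compound 3 to compound 4 (0.48 log units; beyond the scatter). For compound 4 the estimate is 550 ug/mL, with an expected range from 130 ug/mL to 2000 ug/mL.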

Compound 4, half-maximal inhibitory concentration: 20 ug/mL
Compound 4: middle estimate off by 28-fold (1.44 log units), on the high side, outside the stated range (below it).
By their numbers in this assay, from the lowest: compound 4; then compound 2; then compound 1; then compound 3.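

In this assay, the group on this aromatic carbon, ortho to a fluoro group and ortho to a trifluoromethyl group, can move the number sharply downward with the trifluoromethyl group kept in place: 4-aminopiperidin-1-yl in place of piperazin-1-yl gives an 83-fold lower number from compound 3 to compound 4 (1.92 log units; beyond the scatter) and, in place of 3-methyl-3-((methylamino)methyl)pyrrolidin-1-yl, gives a 12-fold lower number from compound 1 to compound 4 (1.06 log units; beyond the scatter) as well. The earlier compounds shown here showed that this position responds to the group on it, but the large step between two six-membered non-aromatic rings with the same printed counts of hydrogen-bond donors and acceptors shows that a small change in the ring is enough. Nothing in hand explains why these two rings differ so widely.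

Going by these compounds, it remains open whether the lower number goes with the amine on the ring carbon or with the ring holding a single hetero atom, and a plain piperidin-1-yl or a 4-(aminomethyl)piperidin-1-yl group on this carbon would help separate the two. On these data alone, it is also open whether the step seen with 4-aminopiperidin-1-yl would hold with fluoro in place of trifluoromethyl, a change that on its own gave a 35-fold higher number from compound 2 to compound 3 (1.55 log units; beyond the scatter) with piperazin-1-yl in the core.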